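A few compounds are considered here, and "the series" means these few. Any claim that something is new, unique, unknown or untested is made for them only; others in the source may bear on it.

Measured so far:
compound 1, `O=C1CC(c2nc(-c3cccc(Cl)c3)no2)CN1c1ccc(Cl)c(Cl)c1`: 460 nM
compound 2, `Cc1ccc(N2CC(c3nc(-c4cccc(Cl)c4)no3)CC2=O)cc1`: 630 nM

Both compounds were tested in an in vitro functional assay on HEK293-A cells for positive allosteric modulation of metabotropic glutamate receptor 5 (Homo sapiens), read by FLIPR and calcium flux; a higher number here means that more compound is needed for the effect, a lower number that less compound is needed. Compound 2 holds the higher of the two numbers, but the gap to compound 1, a 1.4-fold higher number from compound 1 to compound 2 (0.14 log units; within the scatter), lies within the scatter, so the two compounds stand level. Compound 3, `Cc1ccc(N2CC(c3nc(-c4cccc(Cl)c4)no3)CC2=O)cc1C`, differs from compound 2 by methyl in place of hydrogen on an aromatic carbon. Going by the values given here, no measured step adds a methyl to this ring; the only step on record replaces the whole ring on the amide-type nitrogen, and that exchange, a 1.4-fold higher number from compound 1 to compound 2 (0.14 log units; within the scatter), changed little. A smaller change on the same ring gives no reason to expect more. The step is therefore expected to be a 1.1-fold lower number from compound 2 to compound 3 (0.02 log units; within the scatter), no more than the scatter, in no particular direction. For compound 3 the estimated value is 600 nM, with a range from 250 nM to 1500 nM.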

Compound 3, half-maximal effective concentration: 310 nM
Compound 3: middle estimate off by 1.9-fold (0.29 log units), on the high side, within the range that was stated.
By their numbers in this assay, from the lowest: compounds 3, 1 and 2 (each within the scatter of the next, the first and the last beyond it).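

Adding one methyl to the 4-methylphenyl ring, on the aromatic carbon ortho to the existing methyl group, gives a 2.0-fold lower number from compound 2 to compound 3 (0.31 log units; beyond the scatter) in this assay, a modest step but the first one here beyond the scatter, so a change of a single carbon at this position can register. Swapping 3,4-dichlorophenyl for 3,4-dimethylphenyl gives a 1.5-fold lower number from compound 1 to compound 3 (0.17 log units; within the scatter), which lies within the scatter, so these two rings stand level. Nothing available explains why the added methyl has this effect.

From the compounds shown here alone, it remains open whether a larger group at this position, such as an ethyl, a methoxy or an amine, would move the number further. Also open, going by these compounds, is whether this methyl would give the same step on a ring without the 4-methyl group.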